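The source may hold more compounds than are shown below. What is called first, only, known or untested is meant among the compounds shown, and "the series" means these compounds.

Of the compounds shown here, two have so far been tested in a functional assay on HT-29 cells (Homo sapiens) for cytotoxicity, read by resazurin assay, with a stated time of 48 h; on this read-out higher numbers stand for an effect only at larger amounts of compound and lower numbers for an effect already at smaller amounts. Compound 1 `O=C(/C=C/c1ccco1)c1ccc(NC(=O)c2cccs2)cc1` gives 50000 nM in this assay. Compound 2 `CC(=O)Nc1ccc(C(=O)/C=C/c2cccc([N+](=O)[O-])c2)cc1` gives 2000 nM in this assay, the lowest of the two numbers, and its gap to compound 1 lies beyond the usual scatter. Compound 3 `O=C(/C=C/c1cccc([N+](=O)[O-])c1)c1ccc(NC(=O)c2cccs2)cc1` has not yet been measured; it keeps the core of compound 2 and changes a single group: thiophen-2-yl in place of methyl on a carbonyl carbon. Going by the values given here, compound 1 carries the same ((thiophen-2-yl)carbonyl)amino group, but it differs from compound 2 elsewhere too, so no measured pair isolates this one change. In this assay the step is therefore expected to be modest, if present at all: a small shift toward higher numbers is possible, but one staying within the scatter is as plausible. Compound 3 is estimated at 3000 nM, ranging from 800 nM to 15000 nM, which corresponds to an expected step of a 1.5-fold higher number from compound 2 to compound 3 (0.18 log units; within the scatter).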

Compound 3, half-maximal effective concentration: 2500 nM
Estimate against measurement, compound 3: 1.2-fold (0.08 log units) above; the range from low to high includes it.
By their numbers in this assay, from the lowest: compounds 2 and 3 (each within the scatter of the next); then compound 1.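

In this assay, thiophen-2-yl in place of methyl on a carbonyl carbon bound to an amide-type nitrogen gives a 1.3-fold higher number from compound 2 to compound 3 (0.10 log units; within the scatter), so at this position the change from a single carbon to an aromatic ring leaves the number within the scatter. Going by these compounds alone, with thiophen-2-yl held constant, 3-nitrophenyl in place of furan-2-yl on a double-bonded chain carbon bound to a double-bonded chain carbon gives a 20-fold lower number from compound 1 to compound 3 (1.30 log units; beyond the scatter), so this second place in the structure is the one where a large step is seen. No measurement here explains either result.

The compounds shown do not tell whether an amine or a longer chain on that carbonyl carbon would also stay within the scatter of compound 2. They also leave open how much of the large step depends on the nitro group, which a plain phenyl on that chain carbon could help separate from the ring itself.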